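Methoxy in place of hydrogen on compound 2

A few compounds are considered here, and "the series" means these few. Any claim that something is new, unique, unknown or untested is made for them only; others in the source may bear on it.

In a functional assay on MCF7 cells (Homo sapiens) for inhibition, read by colorimetric assay and MTT assay, with a stated time of 72 h (a lower number here means a stronger inhibitor, a higher number a weaker inhibitor), compound 1 (`C=CCCCCOc1ccccc1-c1cnc(OCCCCC=C)n1C`) gives 5000 nM and compound 2 (`C=CCCCCOc1ncc(-c2ccccc2OC)n1C`) gives 5000 nM at the digits shown, so compound 2 stands level with compound 1. Compound 3 (`C=CCCCCOc1ncc(-c2cccc(OC)c2OC)n1C`) differs from compound 2 by methoxy in place of hydrogen on an aromatic carbon. Going by the values given here, the only measured step, no change at the digits printed from compound 1 to compound 2 (within the scatter) at another site, bears on this change only indirectly. Among the compounds with values here, no measured step touches this carbon, and no shift beyond the scatter is expected in this assay on this thin evidence. The expected step is no change at the digits printed from compound 2 to compound 3 (within the scatter) in this estimate. For compound 3 the estimated value is 5000 nM with an expected range from 1800 nM to 14000 nM in the same read-out.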

Compound 3, half-maximal inhibitory concentration: 28000 nM
Compound 3: middle estimate off by 5.6-fold (0.75 log units), on the low side; measured number outside the range, above it.
By their numbers in this assay, from the lowest: compounds 1 and 2 (each within the scatter of the next); then compound 3.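

In this assay, going by these compounds alone, methoxy in place of hydrogen on this aromatic carbon, ortho to a methoxy group and meta to a large group, gives a 5.6-fold higher number from compound 2 to compound 3 (0.75 log units; beyond the scatter) and is the first step beyond the scatter. This carbon therefore responds to substitution, in the direction of weaker inhibition, whereas the earlier step at the other site showed no change. Nothing at hand accounts for this step.

From the compounds shown here alone, whether the higher number is specific to methoxy remains open: a hydroxyl, a fluorine atom or an amine on this carbon would test that. Also open, going by these compounds, is whether methoxy on the other carbons of this ring behaves the same way.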